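Cyclohexyl to Butyl on the Core of Compound 1

The source may hold more compounds than are shown below. What is called first, only, known or untested is meant among the compounds shown, and "the series" means these compounds.

Compound 1 `CN1CCC[C@@H]1Cn1nc(CC2CCCCC2)c2ccccc2c1=O` is known in an assay for binding affinity to Alpha-1B adrenergic receptor (Homo sapiens) (on this read-out higher numbers stand for weaker inhibition and lower numbers for stronger inhibition), only as a limit. In this assay compound 1 gives > 1990 nM, which is a limit of the assay and not a number. The series also holds compound 2 `CN1CCCC1CCn1nc(Cc2ccc(Cl)cc2)c2ccccc2c1=O`, with a different side chain and a different link to the shared core; in this assay compound 2 gives 316 nM. No step between compound 1 and compound 2 is shown, so the two values simply stand side by side. Where compound 1 stands is told by the limit of > 1990 nM in this assay, at which 1 of the 2 values shown sits.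

Compound 3 `CCCCCc1nn(C[C@H]2CCCN2C)c(=O)c2ccccc12` differs from compound 1 in one place: butyl in place of cyclohexyl on a saturated chain carbon bound to an aromatic carbon. Cut one bond further out, the change reads cyclohexylmethyl to pentyl. Going by the values given here, no measured step covers this change, so the expectation rests on compound 1 alone. The expected step is a step that the limit leaves unreadable from compound 1 to compound 3, none beyond the usual scatter and in no fixed direction. For compound 3 the estimate in this assay is 3000 nM, with a range from 800 nM to 15000 nM. A limit rather than a number is again the likelier outcome for compound 3.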

Compound 3, inhibition constant: 1000 nM
Compound 3: middle estimate off by 3.0-fold (0.48 log units), on the high side; low and high end bracket the measured number.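

With butyl in place of cyclohexyl on a saturated chain carbon bound to an aromatic carbon, the series gains a true number at this position: in this assay compound 3 gives 1000 nM. The change amounts to an at least 1.9-fold lower number from compound 1 to compound 3 (0.29 log units; that floor lies within the scatter), so the direction of the step is suggested, but its floor alone does not carry it beyond the scatter. Only that floor can be stated, and the full size of the step stays unknown, because the value of compound 1 is a limit of the assay and not a number: the limit of > 1990 nM in this assay, at which 1 of the 3 values shown sits.

The compounds shown leave open whether the ring itself or the length of the group decides the number here, and a phenyl group in place of cyclohexyl, or a hexyl chain in place of pentyl, would bear on that question. Also open, on these data alone, is whether a chain ending in an amine or a carboxylic acid at this position would keep a number in this assay at all.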